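The compounds below may be only part of what the source reports. "The series", "measured", "known", "first", "only" and "open" are said of these compounds alone.

Measured so far:
Compound 1, `C#Cc1ccnc(C#Cc2ccc3ncn(-c4ccnc(N)n4)c3c2)c1`, in an assay on Sf9 cells for inhibition of mitogen-activated protein kinase kinase kinase 14 variant S549D (Homo sapiens), with a stated time of 30 min, in the presence of a further agent that is not named here (on this read-out higher numbers stand for weaker inhibition and lower numbers for stronger inhibition), gives 316 nM.
Compound 2, `C=Cc1nccc(C#Cc2ccc3ncn(-c4ccnc(N)n4)c3c2)n1`, in this assay gives 39800 nM.

Compound 2 stands at the highest number of the two in this assay, that is, it is the weaker inhibitor; its nearest neighbour is compound 1, and the step of a 130-fold higher number from compound 1 to compound 2 (2.10 log units; beyond the scatter) is a large one. That single measured step swapped a one-heteroatom ring for a two-heteroatom ring on the triple-bonded carbon and cost a great deal.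

Compound 3, `C=Cc1ccc(C#Cc2ccc3ncn(-c4ccnc(N)n4)c3c2)cn1`, differs from compound 2 in one place: a group of 8 heavy atoms (7 carbon, 1 nitrogen; one six-membered aromatic ring with 1 hetero atom) in place of a group of 8 heavy atoms (6 carbon, 2 nitrogen; one six-membered aromatic ring with 2 hetero atoms), on a triple-bonded carbon. This change runs in the opposite sense to the measured step, putting a ring with one hetero atom back where compound 1 also carried one, so the step of a 130-fold higher number from compound 1 to compound 2 (2.10 log units; beyond the scatter) bears directly on it. A large gain in potency, a step well beyond the scatter towards lower numbers, is therefore expected: a 63-fold lower number from compound 2 to compound 3 (1.80 log units; beyond the scatter). Since the vinyl group sits on the ring differently from the ethynyl group of compound 1, a full return to that value is not assured. The estimate for compound 3 in this assay is 630 nM, between 150 nM and 4000 nM.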

Compound 3, half-maximal inhibitory concentration: 79400 nM
Beside the measured number, compound 3's estimate is 130-fold (2.10 log units) below it, and the stated range ends below it.
By their numbers in this assay, from the lowest: compound 1; then compounds 2 and 3 (each within the scatter of the next).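

In this assay, replacing the ring with two hetero atoms by 6-vinylpyridin-3-yl on the triple-bonded carbon gives a 2.0-fold higher number from compound 2 to compound 3 (0.30 log units; within the scatter), so at this position, a ring with one hetero atom in place of one with two brings no readable difference in this pair. A single ring hetero atom is therefore not enough to bring back the stronger inhibition: both 6-vinylpyridin-3-yl and 4-ethynylpyridin-2-yl hold one, yet exchanging the second for the first gives a 250-fold higher number from compound 1 to compound 3 (2.40 log units; beyond the scatter). The position thus distinguishes between these two groups in a way that the count of ring hetero atoms does not capture, and nothing available here explains that difference.

The two groups differ both in the vinyl or ethynyl substituent and in their ring pattern, so the compounds shown cannot say which of these matters, and a 4-vinylpyridin-2-yl group on the same triple-bonded carbon would pull the two apart. Going by these compounds, it also remains open how this position would respond to a pyridine ring carrying a small group of another kind, such as an amine or a methoxy group, in place of the ethynyl group.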